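The compounds below may be only part of what the source reports. "The series", "measured", "known", "first", "only" and "open" are said of these compounds alone.

Measured in a functional assay on MIA PaCa-2 cells (Homo sapiens) for inhibition, read by MTT assay, with a stated time of 3 days; on this read-out higher numbers stand for weaker inhibition and lower numbers for stronger inhibition:
- compound 1 `CCN(CC)S(=O)(=O)c1ccc(S(=O)(=O)N2CCC[C@@H](C(=O)N[C@@H]3CCN(C(=O)OC(C)(C)C)C3)C2)cc1`: 500 nM
- compound 2 `CCOC(=O)[C@@H]1CCCN(S(=O)(=O)c2ccc(S(=O)(=O)N(CC)CC)c(F)c2)C1`: 200 nM

Compound 1 holds the higher of the two numbers, and compound 2 lies lower by more than the scatter. Not yet measured is compound 3 `CCN(CC)S(=O)(=O)c1ccc(S(=O)(=O)N2CCC[C@@H](C(=O)NC3CN(C(=O)OC(C)(C)C)C3)C2)cc1`, which carries 1-(tert-butoxycarbonyl)azetidin-3-yl in place of 1-(tert-butoxycarbonyl)pyrrolidin-3-yl on an amide-type nitrogen. Going by the values given here, no measured pair shows this change, so the expectation rests on compound 1 at 500 nM alone. The expected change in this assay stays within the scatter, as the estimated 1.1-fold lower number from compound 1 to compound 3 (0.05 log units; within the scatter). The estimate for compound 3 is 450 nM, with an expected range of 170 nM to 1100 nM.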

Compound 3, half-maximal inhibitory concentration: 100 nM
Beside the measured number, compound 3's estimate is 4.5-fold (0.65 log units) above it, outside the stated range (below it).
By their numbers in this assay, from the lowest: compounds 3 and 2 (each within the scatter of the next); then compound 1.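

In this assay the substituent on this amide-type nitrogen matters, with a 5.0-fold lower number from compound 1 to compound 3 (0.70 log units; beyond the scatter) when 1-(tert-butoxycarbonyl)azetidin-3-yl replaces 1-(tert-butoxycarbonyl)pyrrolidin-3-yl. The change swaps a five-membered ring for a four-membered one and also removes the defined stereocentre of the leaving group, and this single step cannot separate the two. No measurement at hand accounts for the step. Still open, on these data alone, is whether the tert-butoxycarbonyl group is needed, and how a free azetidine amine or a piperidin-4-yl group would read at this nitrogen.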